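The source may hold more compounds than are shown below. What is called first, only, known or untested is meant among the compounds shown, and "the series" means these compounds.

Compound 1 `Cc1cccc(/C=C2\CCC/C(=C\c3ccccc3)C2=O)c1`: "not determined" (no result reported)
Compound 2 `O=C(/C=C(O)/C=C/c1ccc(O)cc1)c1cc(Cl)ccc1O`: "not determined" (no result reported)
Compound 3 `O=C(/C=C(O)/C=C/c1ccc(O)cc1O)c1ccccc1O`: 40700 nM

Three compounds have been looked at in an assay on isolated protein for inhibition of Alpha glucosidase (Homo sapiens), with stated times of 5 min and 15 min; on this read-out lower numbers stand for stronger inhibition and higher numbers for weaker inhibition. Compound 1 has no result there: in this assay compound 1 gives "not determined" (no result reported). Compound 2 is in the same position, with "not determined" (no result reported) in this assay. Only compound 3 carries a number: in this assay compound 3 gives 40700 nM, which on this read-out is weak inhibition. Compound 1 therefore stands nowhere on the numbers shown; there is no value to place it against, and compound 3 is built on a different core, so its number is only a rough guide to the whole set.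

Compound 4 `O=C1/C(=C/c2ccccc2)CCC/C1=C\c1ccc(O)cc1` keeps the core of compound 1 and differs from it in one place: 4-hydroxyphenyl in place of 3-methylphenyl on a double-bonded chain carbon bound to a double-bonded ring carbon. Going by the values given here, no step between two measured compounds is available, so the size of this change cannot be read from any measured pair. The expectation is a shift no larger than the usual scatter, in no sure direction. Among the compounds with values here, the only anchor is compound 3 at 40700 nM in this assay. For compound 4 the estimate in this assay is 30000 nM, with a range from 5000 nM to 150000 nM.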

Compound 4, half-maximal inhibitory concentration: 42300 nM
Beside the measured number, compound 4's estimate is 1.4-fold (0.15 log units) below it; the range from low to high includes it.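

Going by these compounds alone, compound 1 has no single number in this assay, so no step from it to compound 4 can be read from this result. The compounds shown leave open how 4-hydroxyphenyl in place of 3-methylphenyl changes inhibition on the shared core. Nothing shown here offers an explanation for the result of compound 4.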